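The compounds below may be only part of what the source reports. "The series", "measured", "known", "first", "only" and "open" are said of these compounds alone.

Among the measured compounds shown here, in a functional assay on A-375 cells (Homo sapiens) for cytotoxicity, read by MTT assay, with a stated time of 72 h, tested at 1 uM (a higher number here means more inhibition of growth at the concentration tested, a lower number less inhibition of growth), compound 1 `N/C(=N\NC(=S)N1CCCCCC1)c1ccccn1` gives 67%, the highest of the three numbers measured so far. Compound 2 `N/C(=N\NC(=S)N1CCOCC1)c1ccccn1` gives 26.8% and compound 3 `N/C(=N\NC(=S)N1CCOCC1)c1ccc(F)cn1` gives 44.5%. The difference between the core of compound 1 and the core of compound 2 is not broken down here. Compound 3 differs from compound 2 by a single change, (fluoro in place of hydrogen on an aromatic carbon), and this brought a number 17.7 percentage points higher from compound 2 to compound 3 (beyond the scatter). Compound 4 `N/C(=N\NC(=S)N1CCCCCC1)c1ccc(F)cn1` carries the same change on the core of compound 1: fluoro in place of hydrogen on an aromatic carbon. Compound 1 already stands at 67% in this assay, which leaves less room for a rise of the size seen from compound 2 to compound 3. For compound 4 a smaller rise is therefore expected in this assay, about a number 9 percentage points higher from compound 1 to compound 4 (within the scatter). Compound 4 is accordingly estimated at 76%, with a likely range from 60% to 90%.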

Compound 4, percent growth inhibition at one concentration: 51.8%
For compound 4 the middle estimate is 24.2 percentage points above the measured one; the whole stated range lies above it.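

Fluoro in place of hydrogen on an aromatic carbon gives a number 15.2 percentage points lower from compound 1 to compound 4 (beyond the scatter) in this assay, opposite in direction to the step on the other core. The two steps do not agree, so the change does not carry over as a fixed increment between these cores: the same change on two cores in this assay, a number 17.7 percentage points higher (beyond the scatter) from compound 2 to compound 3 and a number 15.2 percentage points lower (beyond the scatter) from compound 1 to compound 4, 32.9 percentage points apart, beyond the scatter of two such steps. This shows that the outcome of the change depends on the core, but with a single pair per core in one assay it does not show which feature of the cores is responsible.

Open, as far as these compounds go, is whether a chloro or a methoxy group at the same place follows the fluoro result on each core. Also open, from the compounds shown here alone, is how the change behaves on cores beyond these two.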